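A few compounds are considered here, and "the series" means these few. Any claim that something is new, unique, unknown or untested is made for them only; others in the source may bear on it.

Values in a functional assay on NCI-H460 cells (Homo sapiens) for antiproliferative activity (on this read-out higher numbers stand for weaker inhibition and lower numbers for stronger inhibition), for the series so far:
- compound 1 `CC(=O)Nc1ccc(/C=C2/S/C(=N/c3cccc(Cl)c3)NC2=O)cc1` gives 1250 nM
- compound 2 `Cc1ccc(N=C2NC(=O)/C(=C\c3ccc(N(C)C)cc3)S2)cc1` gives 820 nM
- compound 3 `CN(C)c1ccc(/C=C2/SC(=Nc3ccc(O)cc3)NC2=O)cc1` gives 1080 nM

Compound 3 stands within the scatter of both compound 1 and compound 2, so these numbers give no ordering around it. The next compound, compound 4 `CN(C)c1ccc(/C=C2/SC(=Nc3ccccc3)NC2=O)cc1`, has hydrogen in place of hydroxy on an aromatic carbon, so that 4-hydroxyphenyl becomes phenyl (hydrogen in place of hydroxy on an aromatic carbon).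

Going by the values given here, one measured step bears on this place. It is a 1.3-fold higher number from compound 2 to compound 3 (0.12 log units; within the scatter) for hydroxy in place of methyl on an aromatic carbon, and it stays within the scatter. Compound 1 differs from compound 3 in more than one place, so it offers no direct comparison. Among the compounds with values here, no measurement yet shows hydrogen at this place, which makes the read-across indirect.

Since exchanging methyl for hydroxy there left the number within the scatter, no step beyond the scatter is expected in this assay, and neither direction is favoured. The estimated change is a 1.1-fold lower number from compound 3 to compound 4 (0.03 log units; within the scatter) and would lie within the scatter. For compound 4 the expected value is 1000 nM, with an estimated range from 500 nM to 2000 nM in repeated measurements.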

Compound 4, half-maximal inhibitory concentration: 210 nM
Compound 4: middle estimate off by 4.8-fold (0.68 log units), on the high side; the measured number lies below the stated range.
By their numbers in this assay, from the lowest: compound 4; then compounds 2, 3 and 1 (each within the scatter of the next).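

In this assay, this position proves sensitive to substitution: removing the hydroxy of the 4-hydroxyphenyl gives a 5.1-fold lower number from compound 3 to compound 4 (0.71 log units; beyond the scatter), beyond the scatter. Hydrogen in place of methyl at the same aromatic carbon points the same way, with a 3.9-fold lower number from compound 2 to compound 4 (0.59 log units; beyond the scatter), also beyond the scatter, whereas the earlier step, a 1.3-fold higher number from compound 2 to compound 3 (0.12 log units; within the scatter), showed only that hydroxy and methyl lie within the scatter of each other, so their match did not mean that the position tolerates any change; among compounds 2, 3 and 4, the phenyl of compound 4 stands apart from both substituted rings, and none of the three goes against this. No available data explain why hydrogen differs from these two groups here.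

On these data alone, it remains open whether the lower number belongs to hydrogen alone or would also appear with a fluorine, a methoxy group or an amine at this place. As far as these compounds go, compound 1 differs from these compounds in more than one place, so it remains open whether removing a substituent from the ring would have the same effect with the other groups of compound 1.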